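Fluorine Added to a Purine Thioether Series

The source may hold more compounds than are shown below. What is called first, only, known or untested is meant among the compounds shown, and "the series" means these compounds.

Compound 1 `Cn1cnc2c(Sc3ccccc3)ncnc21` is the reference point of this small set. In an assay on isolated protein for inhibition of Rho-associated protein kinase 1 (Homo sapiens), tested at 30 uM (on this read-out higher numbers stand for more inhibition at the one concentration tested (going by the name of the read-out) and lower numbers for less inhibition), compound 1 gives 6%. Compound 2 `Cn1cnc2c(Sc3ccc(F)cc3)ncnc21` carries one change, (fluoro in place of hydrogen on an aromatic carbon); in this assay compound 2 gives 6%, so that no change at the digits printed from compound 1 to compound 2 (within the scatter). Compound 3 `c1ccc(Cn2cnc3c(Sc4ccccc4)ncnc32)cc1` has a different core, and in this assay compound 3 gives 1%; a number 5 percentage points lower from compound 1 to compound 3 (within the scatter), which cannot be told apart from no change at all. The two cores differ by phenyl in place of hydrogen on a saturated chain carbon bound to an aromatic nitrogen.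

Compound 4 `Fc1ccc(Cn2cnc3c(Sc4ccccc4)ncnc32)cc1` has not yet been measured. It differs from compound 3 by fluoro in place of hydrogen on an aromatic carbon. The place of this change is described in exactly the same words as for the change from compound 1 to compound 2, so it is the same change, this time made on the core of compound 3. Resting on the fact that no change at the digits printed from compound 1 to compound 2 (within the scatter), the step expected for compound 4 is a number 1 percentage points higher from compound 3 to compound 4 (within the scatter). Compound 4 is therefore estimated to give 2% in this assay, with a likely range from -5% to 12%.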

Compound 4, a percentage reported as inhibition, at one concentration (the size of the read-out at that concentration, not a potency): 2%
The estimate for compound 4 equals the measured number at the digits printed, and the stated range covers the measured number.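

Fluoro in place of hydrogen on the second core gives a number 1 percentage points higher from compound 3 to compound 4 (within the scatter) in this assay, and 4-fluorophenyl in place of hydrogen on the saturated chain carbon gives a number 4 percentage points lower from compound 1 to compound 4 (within the scatter). The same change therefore reads alike on both cores: the same change on two cores in this assay, no change at the digits printed (within the scatter) from compound 1 to compound 2 and a number 1 percentage points higher (within the scatter) from compound 3 to compound 4, 1 percentage points apart, within the scatter of two such steps

For the compounds shown here, this agreement means only that neither core shows an effect of the fluoro group that could be told apart from scatter, so there is no measurable effect here to carry across; it does not show that the change would behave alike on a core with clearly measurable inhibition.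

Left open is what a different group at the same place on the ring, such as chlorine, methoxy or an amine, would do. Also open, going by these compounds, is whether a carboxylic acid or a longer chain on the aromatic nitrogen would move the number beyond the scatter.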